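The compounds below may be only part of what the source reports. "The series", "measured", "known", "first", "only" and "open" are said of these compounds alone.

Measured so far in a functional assay on PC-3 cells (Homo sapiens) for cytotoxicity, read by WST assay, with a stated time of 72 h; on this read-out higher numbers stand for weaker inhibition and lower numbers for stronger inhibition:

- Compound 1 (`O=C1Nc2c(ccc(F)c2F)C1(c1ccccc1)c1ccc(O)cc1`) gives 8.9 nM
- Compound 2 (`O=C1Nc2c(ccc(F)c2F)C1(c1ccc(O)cc1)c1ccc(F)cc1`) gives 8.6 nM
- Compound 3 (`O=C1Nc2c(ccc(F)c2F)C1(c1ccc(O)cc1)c1cccnc1`) gives > 1000 nM

Compound 3 stands at the weak end of this short series. Its > 1000 nM is a limit of the assay and not a number, which leaves its true value unknown. In compound 4 (`O=C1Nc2c(ccc(F)c2F)C1(CC1CCCCC1)c1ccc(O)cc1`), the rest of the structure stays the same, with cyclohexylmethyl in place of pyridin-3-yl on a saturated ring carbon.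

Among the compounds with values here, two measured steps bear most directly on this change: an at least 110-fold higher number from compound 1 to compound 3 (2.05 log units; beyond the scatter) and an at least 110-fold higher number from compound 2 to compound 3 (2.06 log units; beyond the scatter). Both end at the pyridin-3-yl compound, and read in reverse they show that a ring of carbon only in that spot goes with far lower numbers. A third step, a 1.0-fold lower number from compound 1 to compound 2 (0.01 log units; within the scatter), shows that one fluoro on the phenyl ring made no difference beyond the scatter. Cyclohexylmethyl also lacks the ring nitrogen, but it is non-aromatic, and no measured compound carries such a group. The comparison is therefore a loose one.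

A large move to a lower number is expected, and the estimated step is an at least 25-fold lower number from compound 3 to compound 4 (1.39 log units; beyond the scatter). Compound 4 is estimated at 40 nM, with an expected range from 6 nM to 400 nM.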

Compound 4, half-maximal inhibitory concentration: > 1000 nM
Compound 4 ended at the assay's limit (the forecaster's own chance of this, stated with the estimate: 15%); at least 25-fold (1.39 log units) between middle value and limit.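

Moving to cyclohexylmethyl in this assay gives an at least 110-fold higher number from compound 2 to compound 4 (2.06 log units; beyond the scatter), and likewise an at least 110-fold higher number from compound 1 to compound 4 (2.05 log units; beyond the scatter). Losing the ring nitrogen of compound 3 is therefore not enough on its own: cyclohexylmethyl carries no nitrogen, yet among the four compounds the low numbers at this saturated ring carbon stay with the phenyl of compound 1 and the 4-fluorophenyl of compound 2. The step from compound 3 to compound 4 cannot be read, because the value of each is a limit of the assay and not a number: the limit of > 1000 nM in this assay, at which 2 of the 4 values shown sit.

Cyclohexylmethyl differs from phenyl both in its non-aromatic ring and in the extra carbon that links that ring to the core, so the compounds shown do not separate these two changes, which a benzyl group or a directly attached cyclohexyl would begin to do. Also open, as far as these compounds go, is how this position would respond to a pyridin-4-yl group, with its ring nitrogen in another place, or to a phenyl ring carrying a methoxy group.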